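The compounds below may be only part of what the source reports. "The series", "measured", "known", "first", "only" and "open" are said of these compounds alone.

Compound 3 `CCc1nccn1C[C@@]1(c2ccc(Cl)cc2Cl)OC[C@@H](COc2ccc(N3CCN(c4ccc(-n5cnn(C(C)CC)c5=O)cc4)CC3)cc2)O1` gives 224 nM in a functional assay on HUVEC cells (Homo sapiens), read by scintillation counting and thymidine incorporation, with a stated time of 24 h; on this read-out higher numbers stand for weaker inhibition and lower numbers for stronger inhibition. Among the three measured numbers it has the second highest; compound 2 `CCC(C)n1ncn(-c2ccc(N3CCN(c4ccc(OC[C@@H]5CO[C@@](Cn6ccnc6C)(c6ccc(Cl)cc6Cl)O5)cc4)CC3)cc2)c1=O` is nearest with 173 nM, and compound 1 `CCC(C)n1ncn(-c2ccc(N3CCN(c4ccc(OC[C@@H]5COC(c6ccc(Cl)cc6Cl)O5)cc4)CC3)cc2)c1=O` is furthest with 328 nM. Both gaps are within the scatter, so the three compounds cannot be put in any order on this read-out.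

Compound 4 `CCC(C)n1ncn(-c2ccc(N3CCN(c4ccc(OC[C@@H]5CO[C@@](Cn6ncnn6)(c6ccc(Cl)cc6Cl)O5)cc4)CC3)cc2)c1=O` differs from compound 3 in one place: 2H-tetrazol-2-yl in place of 2-ethyl-1H-imidazol-1-yl on a saturated chain carbon bound to a saturated ring carbon. Within the data shown here, only one measured step touches the same part of the molecule: a 1.3-fold higher number from compound 2 to compound 3 (0.11 log units; within the scatter), a change that stayed within the scatter. Among the measured compounds shown here, no measured pair exchanges one aromatic ring for another at this position, and no measured compound carries a tetrazole at all, so the expectation rests on a thin base. What is known is that neither the methyl-for-hydrogen step nor the gap between compound 1 and compound 3 moved the number beyond the scatter. The expected step of a 1.3-fold higher number from compound 3 to compound 4 (0.13 log units; within the scatter) is therefore none beyond the scatter, with a wide range to cover the untested ring exchange. Compound 4 is estimated at 300 nM, between 100 nM and 900 nM.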

Compound 4, half-maximal inhibitory concentration: 124 nM
For compound 4 the middle estimate is 2.4-fold (0.38 log units) above the measured one; the measured number falls inside the stated range.
By their numbers in this assay, from the lowest: compounds 4, 2, 3 and 1 (each within the scatter of the next, the first and the last beyond it).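

In this assay the exchange on the saturated chain carbon bound to a saturated ring carbon gives a 1.8-fold lower number from compound 3 to compound 4 (0.26 log units; within the scatter) and, starting from the 2-methyl-1H-imidazol-1-yl group, gives a 1.4-fold lower number from compound 2 to compound 4 (0.14 log units; within the scatter) as well. Among these compounds, until now the only change measured at this position was the addition of one methyl to a side chain, whereas these steps replace the whole ring: a five-membered aromatic ring with 2 hetero atoms gives way to one with 4 hetero atoms and fewer heavy atoms, and this read-out does not separate the compounds. Nothing available here explains why the number stays within the scatter across this exchange.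

Going by these compounds, whether this position would accept a group of another kind, such as a primary amine, a carboxylic acid or a longer alkyl chain in place of the aromatic ring, remains open. Also open, on these data alone, is whether an isomeric 1H-tetrazol-1-yl group or a six-membered pyridyl ring would behave like 2H-tetrazol-2-yl, and whether any such group would take the number beyond the scatter.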